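The source may report more compounds than this note shows. Statements on the series, on what has been measured and on what is new or still open speak of the compounds shown alone.

In a functional assay on thoracic aorta (Rattus norvegicus, strain Wistar), with a stated time of 15 min (a higher number here means that more compound is needed for the effect, a lower number that less compound is needed), compound 1 `COc1ccc(Br)cc1C(C)NC(=O)NS(=O)(=O)c1ccccc1` gives > 300000 nM. That value is a limit of the assay and not a number. Two relatives differ from it in the group on the oxygen on the aromatic ring. Compound 2 `CC(NC(=O)NS(=O)(=O)c1ccccc1)c1cc(Br)ccc1OCc1ccccc1`, with benzyl there, gives 130000 nM. Compound 3 `CC(C)Oc1ccc(Br)cc1C(C)NC(=O)NS(=O)(=O)c1ccccc1`, with isopropyl there, gives 143000 nM. The replacements of methyl yield an at least 2.3-fold lower number from compound 1 to compound 2 (0.36 log units; beyond the scatter) and an at least 2.0-fold lower number from compound 1 to compound 3 (0.32 log units; beyond the scatter), while benzyl and isopropyl are separated only by a 1.1-fold higher number from compound 2 to compound 3 (0.04 log units; within the scatter).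

Compound 4 `COc1ccc(F)cc1C(C)NC(=O)NS(=O)(=O)c1ccccc1` keeps the methoxy group and changes the halogen instead: fluoro in place of bromo on an aromatic carbon. This is fluoro in place of bromo on an aromatic carbon, para to the methoxy group. Among the measured compounds shown here, no measured step touches this place, so all three bear on it only indirectly. The two steps out of compound 1 are modest, and they concern the group on the oxygen, which compound 4 leaves unchanged. The expectation in this assay is therefore no step beyond the scatter, and compound 4 may well reach the same assay limit. The estimated change is a number no higher from compound 1 to compound 4 (the limit leaves the size open). For compound 4 the expected value is 300000 nM, with an estimated range from 130000 nM to 600000 nM.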

Compound 4, half-maximal effective concentration: > 300000 nM
Compound 4: a limit, no number; the forecaster's own chance of this, stated with the estimate: 65%; the middle value sits exactly at the limit.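

In this assay compound 4 gives > 300000 nM, which is a limit of the assay and not a number. Compound 1 stands at a limit too, so no step between compound 1 and compound 4 can be read: the limit of > 300000 nM in this assay, at which 2 of the 4 values shown sit.

The compounds shown leave open whether fluoro in place of bromo changes the number at all.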